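This account rests on a few compounds, and the source may have more. Where it says the series, first, only, none or still open, it means among the compounds named here.

Compound 1 `O=C1O/C(=C\Cn2cc(-c3ccc(Br)cc3)nn2)C(OCc2ccccc2)=C1OCc1ccccc1` is one of two measured members of this series. In a functional assay on HeLa cells (Homo sapiens) for antiproliferative activity, read by MTT assay, with a stated time of 72 h (a higher number here means a weaker inhibitor, a lower number a stronger inhibitor), compound 1 gives 24300 nM, the lowest of the two numbers available. Compound 2 `O=C1O[C@H]([C@@H](O)Cn2cc(-c3cccc(O)c3)nn2)C(OCc2ccccc2)=C1OCc1ccccc1` gives in this assay a value of 39300 nM; the two numbers lie within the usual scatter of each other, so no order between compound 1 and compound 2 can be read from them. Among the compounds with values here, no step between measured compounds that differ in a single place is available in this set, so the effect of any one exchange is not yet known.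

Compound 3 `CCCCCc1ccc(-c2cn(C/C=C3\OC(=O)C(OCc4ccccc4)=C3OCc3ccccc3)nn2)cc1` remains to be measured. It differs from compound 1 by pentyl in place of bromo on an aromatic carbon, para to a large group; cut one bond further out, the change reads 4-bromophenyl to 4-pentylphenyl. Within the data shown here, nothing among the measured compounds shows what such an exchange does in this assay. Expected is a step of a 1.6-fold lower number from compound 1 to compound 3 (0.21 log units; within the scatter), a modest gain at most and not clearly beyond the scatter. For compound 3 the expected value in this assay is 15000 nM, with a range from 5000 nM to 50000 nM.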

Compound 3, half-maximal inhibitory concentration: > 100000 nM
Compound 3: only a limit was reported; the forecaster's own chance of this, stated with the estimate: 10%; at least 6.6-fold (0.82 log units) between middle value and limit.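

The series now has its first step in a single place: pentyl in place of bromo on an aromatic carbon, para to a large group, gives an at least 4.1-fold higher number from compound 1 to compound 3 (0.61 log units; beyond the scatter) in this assay. This position therefore responds to the group placed on it, which compound 1 and compound 2 could not show, as they differ in more than one place and their values lie within the scatter of each other. The value of compound 3, > 100000 nM, is a limit of the assay and not a number, so the full size of the step cannot be read: the limit of > 100000 nM in this assay, at which 1 of the 3 values shown sits.

Still open, from the compounds shown here alone, is whether the loss follows from the pentyl chain as such or from the departure of bromo, as only these two groups at this position can be compared in a single step. Going by these compounds, a shorter chain such as methyl or ethyl, a methoxy group or an amine at the same place would separate these readings, and whether pentyl acts the same way on the core of compound 2 also remains open.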